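A few compounds are considered here, and "the series" means these few. Any claim that something is new, unique, unknown or untested is made for them only; others in the source may bear on it.

Measured in a functional assay on HeLa cells (Homo sapiens) for cytotoxicity, read by MTT assay, with a stated time of 48 h; on this read-out lower numbers stand for stronger inhibition and higher numbers for weaker inhibition:
- compound 1 `COc1cc([C@@H]2C[C@@]2(CO)C(=O)Nc2ccccc2)cc(OC)c1OC`: 86400 nM
- compound 2 `COc1cc([C@@H]2C[C@@]2(CO)C(=O)Nc2ccccc2Cl)cc(OC)c1OC`: 13300 nM
- compound 3 `CCOC(=O)[C@@]1(C(=O)Nc2ccccc2)C[C@H]1c1cc(OC)c(OC)c(OC)c1`: > 100000 nM (a limit, not a number)

Compound 1 holds the higher of the two true numbers, at 86400 nM. Compound 3 gives no true number, and its entry marks (the limit of > 100000 nM in this assay, at which 1 of the 3 values shown sits).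

Compound 4 `COc1cc([C@@H]2C[C@]2(CO)C(=O)Nc2ccccc2)cc(OC)c1OC` is the next case, and its relation to the first compound is simple to state: the two compounds have the same atoms and bonds and differ only in configuration as drawn: 1 of 2 stereo elements differ; a stereocentre at a saturated ring carbon is drawn R in compound 1 and S in compound 4. Nothing is added or taken away, so only the drawn configuration at that ring carbon separates them.

Two measured steps start from compound 1. Placing chloro in place of hydrogen on an aromatic carbon gave a 6.5-fold lower number from compound 1 to compound 2 (0.81 log units; beyond the scatter). Placing ethoxycarbonyl in place of hydroxymethyl on a saturated ring carbon gave an at least 1.1-fold higher number from compound 1 to compound 3 (0.06 log units; that floor lies within the scatter). Both steps swap one group for another, and neither alters configuration, so neither shows directly what the new change will do. Among the compounds with values here, with no measured pair of this kind, no step beyond the scatter is expected in this assay, and no firm direction can be given. The estimated change is a 1.2-fold lower number from compound 1 to compound 4 (0.09 log units; within the scatter). For compound 4 the expected value is 70000 nM, with an estimated range from 20000 nM to 140000 nM.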

Compound 4, half-maximal inhibitory concentration: 32000 nM
Beside the measured number, compound 4's estimate is 2.2-fold (0.34 log units) above it, within the range that was stated.
By their numbers in this assay, from the lowest: compound 2; then compound 4; then compound 1. At a limit, above all of these: compound 3.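

In this assay, the drawn configuration at this saturated ring carbon moves the number by itself: switching that stereocentre from R to S gives a 2.7-fold lower number from compound 1 to compound 4 (0.43 log units; beyond the scatter). The earlier steps each swapped one group for another, so none of them could show this, whereas here the step can be laid on that single stereocentre, and the reason is plain: the fact that compounds 1 and 4 differ only in the configuration as drawn. At this carbon, then, the arrangement in space matters as well as the group attached, although this rests on one pair of compounds and says nothing yet about any other pair.

The compounds shown leave open whether the same switch would also lower the number in compound 2, which carries the chloro group, and what would happen if the other stereocentre were drawn the opposite way. They also do not tell how an aminomethyl group or a carboxylic acid in place of hydroxymethyl at this ring carbon would behave in either configuration.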